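Isopropyl for Methoxy on a Weak Glucuronidase Inhibitor

This account rests on a few compounds, and the source may have more. Where it says the series, first, only, none or still open, it means among the compounds named here.

In an assay for inhibition of beta-glucuronidase (Bos taurus), read by spectrophotometry, with a stated time of 30 min (on this read-out higher numbers stand for weaker inhibition and lower numbers for stronger inhibition), compound 1 `COC(=O)C1=C(C)NC(=O)NC1c1ccc(OC)cc1` gives 59200 nM. Compound 3 `COC(=O)C1=C(C)NC(=O)NC1c1cc(OC)c(O)c(OC)c1` gives 34200 nM in this assay, and this number lies within the scatter of the number for compound 1, so the two compounds cannot be told apart on this read-out. Compound 2 `COC(=O)C1=C(C)NC(=O)NC1c1ccc(OC)c(OC)c1` is reported in this assay as "not active" (no number reported), with no number given. Compound 4 `COC(=O)C1=C(C)NC(=O)NC1c1ccc(C(C)C)cc1` differs from compound 1 by isopropyl in place of methoxy on an aromatic carbon. Among the measured compounds shown here, no measured pair shows this change, so these data give no direction for it. Compound 4 is therefore expected to give 50000 nM, with a range from 15000 nM to 200000 nM. The step from compound 1 to compound 4 is expected to be a 1.2-fold lower number from compound 1 to compound 4 (0.07 log units; within the scatter), no more than the scatter.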

Compound 4, half-maximal inhibitory concentration: "not active" (no number reported)
Nothing numeric was reported for compound 4, and the estimate cannot be compared.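

Compound 4 is reported as "not active" without a number, so no step from compound 1 to compound 4 can be read, and nothing shown bears on this result. Compound 4 carries isopropyl in place of methoxy. The compounds shown leave open the size of the step between compound 1 and compound 4 in this assay.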